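The source may hold more compounds than are shown below. What is called first, only, known or untested is meant among the compounds shown, and "the series" means these compounds.

Three compounds sharing one core have been examined in a functional assay on BGC-823 cells (Homo sapiens) for antiproliferative activity, read by MTT assay, tested at 1 uM; a lower number here means a weaker effect, a higher number a stronger effect of the compound at the concentration tested. Compound 1 `COc1cc(C2=NN(C(C)=O)C(c3cccc(F)c3)O2)cc(OC)c1OC` gives 14.7%, compound 2 `COc1ccc(C2OC(c3cc(OC)c(OC)c(OC)c3)=NN2C(C)=O)c(OC)c1` gives 6.3%, and compound 3 `COc1cc(C2=NN(C(C)=O)C(c3c(Cl)cccc3Cl)O2)cc(OC)c1OC` gives -1.4%, the lowest of the three numbers, set apart beyond the scatter only from compound 1. The steps into compound 3 are a number 16.1 percentage points lower from compound 1 to compound 3 (beyond the scatter) and a number 7.7 percentage points lower from compound 2 to compound 3 (within the scatter). Compound 4 `COc1cc(C2=NN(C(C)=O)C(c3ccc(Cl)c([N+](=O)[O-])c3)O2)cc(OC)c1OC` differs from compound 3 by 4-chloro-3-nitrophenyl in place of 2,6-dichlorophenyl on a saturated ring carbon. For the measured compounds named here, no measured step carries the entering group, so these two steps are the only guide: each lowered the number when 2,6-dichlorophenyl entered, and leaving it is expected to bring a small rise in this assay, likely not beyond the scatter. Compound 4 is expected at 8%, between -6% and 24%, a step of a number 9.4 percentage points higher from compound 3 to compound 4 (within the scatter).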

Compound 4, a percentage reported as inhibition, at one concentration (the size of the read-out at that concentration, not a potency): -2.3%
Compound 4: middle estimate off by 10.3 percentage points, on the high side, and the stated range covers the measured number.
By their numbers in this assay, from the lowest: compounds 4, 3, 2 and 1 (each within the scatter of the next, the first and the last beyond it).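

At this saturated ring carbon in this assay, 4-chloro-3-nitrophenyl is not separated from 2,6-dichlorophenyl, with a number 0.9 percentage points lower from compound 3 to compound 4 (within the scatter) on the change, or from 2,4-dimethoxyphenyl, with a number 8.6 percentage points lower from compound 2 to compound 4 (within the scatter) on the change. Against 3-fluorophenyl the result is a number 17 percentage points lower from compound 1 to compound 4 (beyond the scatter) and so compound 1 now stands apart from two different groups rather than one. Nothing available explains these steps. Still open, from the compounds shown here alone, is whether an amine or a carboxylic acid on this phenyl ring, or a longer chain in its place, would move the number in this assay beyond the scatter.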